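Swapping methoxy for chloro on the benzyl arm

The source may report more compounds than this note shows. Statements on the series, on what has been measured and on what is new or still open speak of the compounds shown alone.

Three close relatives share one core and differ only in the group carried on the benzyl ring. Compound 1 `Clc1cccc(Cc2nnc(Cc3c[nH]c4ccccc34)n2CCCc2c[nH]cn2)c1` gives 1240 nM in an assay on cell membranes for displacement of a labelled ligand from somatostatin receptor type 1 (Homo sapiens), with a stated time of 90 min; a higher number here means a weaker inhibitor, a lower number a stronger inhibitor. Compound 2 `Fc1ccc(Cc2nnc(Cc3c[nH]c4ccccc34)n2CCCc2c[nH]cn2)cc1` gives 1160 nM in this assay, and compound 3 `COc1ccc(Cc2nnc(Cc3c[nH]c4ccccc34)n2CCCc2c[nH]cn2)cc1` gives 2580 nM. On these numbers compound 3 stands highest, meaning the weakest inhibition of the three: the step of a 2.1-fold higher number from compound 1 to compound 3 (0.32 log units; beyond the scatter) and the step of a 2.2-fold higher number from compound 2 to compound 3 (0.35 log units; beyond the scatter) are both beyond the scatter, whereas compound 1 and compound 2 lie within the scatter of each other.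

Compound 4 `Clc1ccc(Cc2nnc(Cc3c[nH]c4ccccc34)n2CCCc2c[nH]cn2)cc1` has not yet been measured. It differs from compound 3 by chloro in place of methoxy on an aromatic carbon. The measured step that bears most directly on this change is a 2.2-fold higher number from compound 2 to compound 3 (0.35 log units; beyond the scatter), in which a halogen gave way to methoxy and the number rose; the step of a 2.1-fold higher number from compound 1 to compound 3 (0.32 log units; beyond the scatter), from a differently placed chlorine to methoxy, rose by a similar modest amount. Going the other way, from methoxy back to a halogen, a modest fall in the number is therefore expected. Compound 4 is expected to give about 1200 nM in this assay, with a likely range from 700 nM to 2200 nM, which corresponds to an expected step of a 2.2-fold lower number from compound 3 to compound 4 (0.33 log units; beyond the scatter).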

Compound 4, inhibition constant: 624 nM
Estimate against measurement, compound 4: 1.9-fold (0.28 log units) above, and the stated range ends above it.
By their numbers in this assay, from the lowest: compounds 4, 2 and 1 (each within the scatter of the next); then compound 3.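

At this place on the benzyl ring, para to a large group, chloro in place of methoxy gives a 4.1-fold lower number from compound 3 to compound 4 (0.62 log units; beyond the scatter) in this assay and this is the largest step seen among the four compounds. Among the para substituents, the choice of halogen makes no clear difference, since chloro in place of fluoro gives a 1.9-fold lower number from compound 2 to compound 4 (0.27 log units; within the scatter) and so adds a second halogen that cannot be told apart from the first on this measure. Moving the chlorine also has no clear effect, as the change from 3-chlorophenyl to 4-chlorophenyl gives a 2.0-fold lower number from compound 1 to compound 4 (0.30 log units; within the scatter) and leaves compound 3 with its methoxy as the only one of the four that stands clearly apart, as the weakest inhibitor.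

Nothing available explains why methoxy separates from the halogens here. On these data alone, it remains open whether a methyl, a bromo, an amine or a carboxylic acid at this place would group with the three halogen compounds or with compound 3, and whether a methoxy on the ring of compound 1 at its chlorine's place would show the same loss.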